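Back from a fused two-ring arm to a single phenyl

The compounds below may be only part of what the source reports. "The series", "measured", "known", "first", "only" and "open" are said of these compounds alone.

Compound 1 `COc1cc(-c2ccnc3cc(-c4ccc(C)cc4)nn23)cc(OC)c1OC` gives 21 nM in a functional assay on HeLa cells (Homo sapiens) for inhibition, read by CCK-8 assay, with a stated time of 48 h; on this read-out higher numbers stand for weaker inhibition and lower numbers for stronger inhibition.
Compound 2 `COc1cc(-c2ccnc3cc(-c4ccc5ccn(C)c5c4)nn23)cc(OC)c1OC` gives 187 nM in this assay.
Compound 3 `COc1cc(-c2ccnc3cc(-c4ccc5cnn(C)c5c4)nn23)cc(OC)c1OC` gives 97 nM in this assay.

Compound 3 stands second highest of the three numbers; compound 2 lies within the scatter of it, while the step of a 4.6-fold higher number from compound 1 to compound 3 (0.66 log units; beyond the scatter) was beyond the scatter. Compound 4 `COc1ccc(-c2cc3nccc(-c4cc(OC)c(OC)c(OC)c4)n3n2)cc1` differs from compound 3 in one place: 4-methoxyphenyl in place of 1-methyl-1H-indazol-6-yl on an aromatic carbon. The group that enters, like the 4-methylphenyl of compound 1, is a single six-membered ring of carbon only, whereas compound 2 and compound 3 carry a fused two-ring group. The steps of an 8.9-fold higher number from compound 1 to compound 2 (0.95 log units; beyond the scatter) and a 4.6-fold higher number from compound 1 to compound 3 (0.66 log units; beyond the scatter) both gave modestly higher numbers when a fused group replaced 4-methylphenyl, so undoing that is expected to lower the number: compound 4 is expected to show a 3.2-fold lower number from compound 3 to compound 4 (0.51 log units; beyond the scatter). The estimate for compound 4 is 30 nM, ranging from 12 nM to 90 nM, the range kept wide because only compound 1, with a methyl rather than a methoxy group, gave 21 nM.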

Compound 4, half-maximal inhibitory concentration: 373 nM
Compound 4: middle estimate off by 12-fold (1.09 log units), on the low side, and the stated range ends below it.
By their numbers in this assay, from the lowest: compound 1; then compounds 3, 2 and 4 (each within the scatter of the next, the first and the last beyond it).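

A single ring alone does not restore the low number: a 3.8-fold higher number from compound 3 to compound 4 (0.58 log units; beyond the scatter) with 4-methoxyphenyl replacing the fused group, while a 2.0-fold higher number from compound 2 to compound 4 (0.30 log units; within the scatter) leaves those two compounds level. The largest change comes on the single ring itself, where methoxy replacing methyl gives an 18-fold higher number from compound 1 to compound 4 (1.25 log units; beyond the scatter) and shows that this position responds strongly to the group carried by that ring. Nothing available explains this difference.

Still open, from the compounds shown here alone, is whether a chloro, hydroxy or dimethylamino group on that ring would give a number nearer compound 1 or compound 4.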